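The source may report more compounds than this note shows. Statements on the series, on what has been measured and on what is new or still open speak of the compounds shown alone.

Measured so far in a functional assay on A-431 cells (Homo sapiens) for antiproliferative activity, read by MTT assay, with a stated time of 72 h; a lower number here means a stronger inhibitor, a higher number a weaker inhibitor:
Compound 1 `C#Cc1cccc(Nc2ncnc3ccc(NC(=O)Nc4ccc(CN5CCN(C)CC5)cc4)cc23)c1` gives 2810 nM.
Compound 2 `CN1CCN(Cc2ccc(NC(=O)Nc3ccc4ncnc(Nc5ccc(F)c(F)c5)c4c3)cc2)CC1` reaches only the limit of the assay, > 10000 nM.
Compound 3 `CN1CCN(Cc2ccc(NC(=O)Nc3ccc4ncnc(Nc5cccc(C(F)(F)F)c5)c4c3)cc2)CC1` gives 2410 nM.

Compound 3 stands lowest of the two numbers shown, and compound 1 is nearest by a 1.2-fold lower number from compound 1 to compound 3 (0.07 log units; within the scatter), a gap within the scatter. Compound 2 sits at the limit (the limit of > 10000 nM in this assay, at which 1 of the 3 values shown sits).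

Compound 4 `CCN(CC)c1ccc(NC(=O)Nc2ccc3ncnc(Nc4cccc(C(F)(F)F)c4)c3c2)cc1` differs from compound 3 by diethylamino in place of (4-methylpiperazin-1-yl)methyl on an aromatic carbon. Every measured step concerns the group on the nitrogen of the core instead: an at least 3.5-fold higher number from compound 1 to compound 2 (0.55 log units; beyond the scatter), an at least 4.1-fold lower number from compound 2 to compound 3 (0.61 log units; beyond the scatter) and a 1.2-fold lower number from compound 1 to compound 3 (0.07 log units; within the scatter). Within the data shown here, none touches the place altered here, so no measured step bears on the change, and compound 4 is expected to give a number close to that of compound 3, with no step beyond the scatter. Compound 4 is therefore estimated at 3500 nM, between 1400 nM and 9000 nM, a step of a 1.5-fold higher number from compound 3 to compound 4 (0.16 log units; within the scatter).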

Compound 4, half-maximal inhibitory concentration: 6460 nM
Estimate against measurement, compound 4: 1.8-fold (0.27 log units) below, within the range that was stated.
By their numbers in this assay, from the lowest: compounds 3 and 1 (each within the scatter of the next); then compound 4. At a limit, above all of these: compound 2.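

In this assay the aromatic carbon that carries (4-methylpiperazin-1-yl)methyl proves sensitive to change: diethylamino in its place gives a 2.7-fold higher number from compound 3 to compound 4 (0.43 log units; beyond the scatter) and removes the six-membered non-aromatic ring. The earlier steps shown here all concerned the group on the nitrogen of the core and could not show this. Nothing measured here accounts for this step.

The compounds shown do not separate the contribution of the piperazine ring from that of its methylene link, as a diethylaminomethyl or morpholin-4-ylmethyl group would. Going by these compounds, it also remains open whether the step holds with 3-ethynylphenyl on the nitrogen of the core.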